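The source may report more compounds than this note shows. Statements on the series, on what has been measured and on what is new or still open speak of the compounds shown alone.

Measured in a physicochemical assay for lipophilicity, read by HPLC, measured as octanol-water partition, at pH 7.2; a lower number here means a more polar compound, a higher number a more lipophilic compound:
- Compound 1 `CC(=O)c1ccc(NC(=O)Nc2ccc(F)c(C(F)(F)F)c2)cc1`: 3.6
- Compound 2 `Cc1cc(NC(=O)Nc2ccc(F)c(C(F)(F)F)c2)on1`: 3.2

Compound 1 stands higher of the two, and its gap to compound 2 lies beyond the scatter. Compound 3 `NC(=O)c1ccc(NC(=O)Nc2ccc(F)c(C(F)(F)F)c2)cc1`, not yet measured, has amino in place of methyl on a carbonyl carbon, a change that also reads acetyl to carbamoyl. Among the measured compounds shown here, no step between measured compounds offers a guide, so the expectation rests on the structural change alone: a clear step downward in this assay, beyond the scatter. The estimated change is a number 0.80 log units lower from compound 1 to compound 3 (beyond the scatter). Compound 3 is expected at 2.8, with an estimated range from 2.3 to 3.2.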

Compound 3, distribution coefficient: 2.7
Compound 3: the middle estimate sits 0.10 log units above what was measured, within the range that was stated.
By their numbers in this assay, from the lowest: compound 3; then compound 2; then compound 1.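

In this assay, amino in place of methyl on a carbonyl carbon gives a number 0.90 log units lower from compound 1 to compound 3 (beyond the scatter). Among the compounds shown here, this is the first step between compounds that differ in one place, and it shows that exchanging one heavy atom at this position, with one hydrogen-bond donor entering and no net charge, is enough to move the number beyond the scatter. Nothing available accounts for the size of this step. The compounds shown leave open how a methylamino or dimethylamino group on this carbonyl carbon would read, and where a carboxylic acid would fall relative to compound 3.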